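The source may hold more compounds than are shown below. What is called first, only, known or untested is meant among the compounds shown, and "the series" means these compounds.

Measured compounds:
compound 1 `COc1cc(-c2nn(-c3cccc(NC(=O)Nc4ccc(Cl)c(Cl)c4)c3)cc2-c2ccncc2)ccc1Cl`; compound 2 `COc1cc(-c2nn(-c3cccc(NC(=O)c4ccc(Cl)c(C(F)(F)F)c4)c3)cc2-c2ccncc2)ccc1Cl`.

In a functional assay on HOP-62 cells (Homo sapiens) for inhibition, read by sulforhodamine B assay, with a stated time of 48 h (on this read-out lower numbers stand for higher toxicity in this test and higher numbers for lower toxicity in this test), compound 1 gives > 50000 nM, a limit of the test. In this assay compound 2 gives > 32500 nM, again a limit. Compound 2 thus stands at the limit (the limit of > 32500 nM in this assay, at which 1 of the 2 values shown sits), and compound 1 sits at the limit (the limit of > 50000 nM in this assay, at which 1 of the 2 values shown sits). The step that the two limits leave unreadable from compound 1 to compound 2 is therefore of unreadable size.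

Compound 3 `COc1cc(-c2nn(-c3cccc(NC(=O)Nc4ccc(Cl)c(C(F)(F)F)c4)c3)cc2-c2ccncc2)ccc1Cl` differs from compound 2 by (4-chloro-3-(trifluoromethyl)phenyl)amino in place of 4-chloro-3-(trifluoromethyl)phenyl on a carbonyl carbon. Going by the values given here, only the step from compound 1 to compound 2 bears on this change, and its size cannot be read. No step beyond the scatter is expected: the step that the limit leaves unreadable from compound 2 to compound 3 is the estimate. Compound 3 is accordingly expected at 50000 nM, within 20000 nM to 100000 nM.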

Compound 3, concentration lethal to 50% of the cells: 31000 nM
Compound 3: middle estimate off by 1.6-fold (0.21 log units), on the high side; measured number inside the range.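

In this assay, going by these compounds alone, compound 3 gives 31000 nM, the first value that is a number and not a limit. With (4-chloro-3-(trifluoromethyl)phenyl)amino on the carbonyl carbon there is an at least 1.0-fold lower number from compound 2 to compound 3 (0.02 log units; that floor lies within the scatter), and with trifluoromethyl in place of chloro on an aromatic carbon there is an at least 1.6-fold lower number from compound 1 to compound 3 (0.20 log units; that floor lies within the scatter). Both are floors only, so neither change is shown to shift the read-out beyond the scatter.

From the compounds shown here alone, compound 1 and compound 2 stand at limits, and the true size of both steps stays open. Also open, going by these compounds, is the read-out with an amine in place of trifluoromethyl on an aromatic carbon.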